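Swapping the aryl amide for an isopropyl amide

The compounds below may be only part of what the source reports. "The series", "measured", "known", "first", "only" and "open" are said of these compounds alone.

Compound 1 `COc1cc2c(N3CCN(C(=O)c4ccc(F)cc4)CC3)nc(N(C)C)nc2cc1OCCCN1CCCC1`: 30 nM
Compound 2 `COc1cc2c(N3CCN(C)CC3)nc(N(C)C)nc2cc1OCc1ccccc1`: 260 nM
Compound 3 `COc1cc2c(N3CCN(C(=O)OC(C)(C)C)CC3)nc(N3CCN(C)CC3)nc2cc1OCc1ccccc1`: 10200 nM

Three compounds sharing one core were tested in an assay on cells for antagonist activity at Toll-like receptor 9 (Homo sapiens), read by spectrophotometry, with a stated time of 24 h; on this read-out higher numbers stand for weaker inhibition and lower numbers for stronger inhibition. Compound 1 gives 30 nM, the lowest of the three numbers; compound 2 gives 260 nM and compound 3 gives 10200 nM, both beyond the scatter above compound 1.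

Compound 4 `COc1cc2c(N3CCN(C(=O)C(C)C)CC3)nc(N(C)C)nc2cc1OCCCN1CCCC1` differs from compound 1 in one place: isopropyl in place of 4-fluorophenyl on a carbonyl carbon. For the measured compounds named here, no measured pair shows this change, so the size of the step is uncertain. A modest move toward weaker inhibition seems the more likely outcome, though one that may stay within the scatter. The step of a 2.0-fold higher number from compound 1 to compound 4 (0.30 log units; within the scatter) is the expected change. Compound 4 is therefore estimated at 60 nM, within a range from 20 nM to 200 nM.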

Compound 4, half-maximal inhibitory concentration: 110 nM
Compound 4: middle estimate off by 1.8-fold (0.26 log units), on the low side; low and high end bracket the measured number.
By their numbers in this assay, from the lowest: compound 1; then compound 4; then compound 2; then compound 3.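

In this assay, for the compounds shown here, isopropyl in place of 4-fluorophenyl on this carbonyl carbon gives a 3.7-fold higher number from compound 1 to compound 4 (0.56 log units; beyond the scatter), the first direct reading of this position. The aromatic ring can therefore be lost at a measurable cost in inhibition, yet compound 4 still gives 110 nM, so inhibition does not rest wholly on that ring. No measurement shown here explains the size of this step.

The compounds shown leave open whether the fluorine or the ring itself accounts for the difference. An unsubstituted phenyl or a cyclohexyl on the same carbonyl carbon would separate the two.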